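A few compounds are considered here, and "the series" means these few. Any claim that something is new, unique, unknown or untested is made for them only; others in the source may bear on it.

Compound 1 `CCOC(=O)c1ccc(-c2nn(Cc3cccc(Cl)c3)c3ccccc23)cc1`: > 10000 nM
Compound 2 `CCCn1nc(-c2ccc(C(=O)OCC)cc2)c2ccccc21`: > 10000 nM

In a functional assay on cells (Platelet, Homo sapiens) for inhibition (a higher number here means a weaker inhibitor, a lower number a stronger inhibitor), compound 2 gives > 10000 nM, which is a limit and not a number. The value of compound 1 is a limit too. Compound 3 `CCCCn1nc(-c2ccc(C(=O)OCC)cc2)c2ccccc21` differs from compound 2 by one change: methyl in place of hydrogen on a saturated chain carbon, three bonds along the chain from an aromatic nitrogen, which turns propyl into butyl. Among the compounds with values here, the only measured step that bears on this is a step that the two limits leave unreadable from compound 1 to compound 2, and its size is hidden because of the limit of > 10000 nM in this assay, at which 2 of the 2 values shown sit. With no readable step to guide it, no clear shift beyond the scatter is expected in this assay. The estimated step is a step that the limit leaves unreadable from compound 2 to compound 3. Compound 3 is expected at about 15000 nM, with an estimated range of 5000 nM to 50000 nM.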

Compound 3, half-maximal inhibitory concentration: > 10000 nM
Compound 3 was reported as a limit; the forecaster's own chance of this, stated with the estimate: 85%; the middle value lies beyond the limit too.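

Compound 3 is also reported only as a limit, so no step among compound 1, compound 2 and compound 3 can be read: the limit of > 10000 nM in this assay, at which 3 of the 3 values shown sit.

The compounds shown leave open how strongly any of them inhibits, and whether changing the chain on the aromatic nitrogen matters at all.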